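The source may report more compounds than this note shows. Statements on the series, on what has been measured and on what is new or still open speak of the compounds shown alone.

The series opens with compound 1, `COc1cc2ncnc(-n3nc(Nc4ccc(N5CCN(C6CC7CCC6C7)CC5)c(Cl)c4)nc3N)c2cc1OC`, which in an ADME assay on the whole organism (strain Sprague-Dawley) for pharmacokinetics, with Rattus norvegicus as the target (on this read-out lower numbers stand for slow clearance and higher numbers for fast clearance), gives 117 mL/min/kg. Two further analogues share the bridged bicyclic amine on the piperazine but carry other fused six-membered heteroaromatic groups on the aminotriazole: compound 2, `Cc1nc(-n2nc(Nc3ccc(N4CCN(C5CC6CCC5C6)CC4)cc3)nc2N)c2ccccc2n1`, for which this assay reports "not determined" (no result reported), and compound 3, `Nc1nc(Nc2ccc(N3CCN(C4CC5CCC4C5)CC3)cc2)nn1-c1ncnc2ccc(Cl)cc12`, for which this assay likewise reports "not determined" (no result reported). For the measured compounds named here, compound 3 therefore has no single number on this read-out, and the same is true of one other entry in the set, so no measured step anchors the position of compound 3 against compound 1.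

Compound 4, `Nc1nc(Nc2ccc(N3CCN(C4CC5CCC4C5)CC3)cc2)nn1-c1ncnc2ccc(F)cc12`, has not been run in this assay. It differs from compound 3 in one place: fluoro in place of chloro on an aromatic carbon. Cut one bond further out, the exchange reads 6-chloroquinazolin-4-yl to 6-fluoroquinazolin-4-yl.

Going by the values given here, with no step between measured compounds on file and no number for compound 3, the size of the move in this assay cannot be predicted from the data; the most defensible expectation is a change no larger than the usual scatter, in no particular direction. Resting on the only number available, that of compound 1 at 117 mL/min/kg, the clearance of compound 4 is estimated at 80 mL/min/kg, with a plausible range from 30 mL/min/kg to 150 mL/min/kg.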

Compound 4, clearance: 44 mL/min/kg
Compound 4: middle estimate off by 1.8-fold (0.26 log units), on the high side; the measured number falls inside the stated range.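

In this assay compound 4 gives 44 mL/min/kg while compound 3 has no single number, so the exchange of chloro for fluoro cannot be read as a step. The compounds shown leave open whether that exchange changes clearance at all, and in which direction. No supporting data bear on this result.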